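Adding a Methyl Group to Compound 3

This account rests on a few compounds, and the source may have more. Where it says the series, first, only, none or still open, it means among the compounds named here.

In a functional assay on A549 cells (Homo sapiens) for cytotoxicity (a lower number here means that less compound is needed, a higher number that more compound is needed for the effect), compound 1 (`COC1=C(C)C(=O)/C(=C(O)/C=C/c2ccccc2C)C(=O)C1(C)C`) gives 4.6 ug/mL, compound 2 (`CCc1ccc(/C=C/C(O)=C2/C(=O)C(C)=C(OC)C(C)(C)C2=O)cc1`) gives 6.1 ug/mL and compound 3 (`CCC1=C(OC)C(CC)(CC)C(=O)C(C(=O)/C=C/c2ccccc2)=C1O`) gives 3.4 ug/mL. These three numbers lie within the scatter of one another, so compound 3 cannot be separated from the other two. Compound 4 (`CCC1=C(OC)C(CC)(CC)C(=O)C(C(=O)/C=C/c2ccc(C)cc2)=C1O`) differs from compound 3 in one place: methyl in place of hydrogen on an aromatic carbon. This is methyl in place of hydrogen on an aromatic carbon, para to a large group. Among the measured compounds shown here, only one measured step bears on this change, and only indirectly. Replacing 2-methylphenyl with 4-ethylphenyl on the core of compound 1 gives a 1.3-fold higher number from compound 1 to compound 2 (0.12 log units; within the scatter), a change in the same aromatic substituent that stays within the scatter. For the measured compounds named here, no measured pair isolates this methyl group on the core of compound 3. A step beyond the scatter is therefore not expected in this assay. The expected change is a 1.2-fold higher number from compound 3 to compound 4 (0.07 log units; within the scatter), which remains within the scatter. For compound 4 the estimated value is 4 ug/mL, with an expected range from 2 ug/mL to 8 ug/mL.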

Compound 4, concentration for half-maximal effect: 4.6 ug/mL
Compound 4: the middle estimate sits 1.2-fold (0.06 log units) below what was measured, within the range that was stated.
By their numbers in this assay, from the lowest: compounds 3, 1, 4 and 2 (each within the scatter of the next).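

In this assay, the methyl group on this aromatic carbon now has a direct reading on the core of compound 3, a 1.4-fold higher number from compound 3 to compound 4 (0.13 log units; within the scatter). The earlier step from compound 1 to compound 2 exchanged one substituted phenyl group for another on a different core, whereas this pair isolates a single methyl group para to a large group. Phenyl and 4-methylphenyl therefore cannot be told apart here, and nothing available offers an explanation for that result.

The compounds shown leave open whether an amine or a carboxylic acid on this same aromatic carbon would give a step beyond the scatter. They also leave open whether a longer chain at this place, such as propyl, would do so on the core of compound 3.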